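Shortening the sulfonyl alkyl group of compound 1

The source may hold more compounds than are shown below. What is called first, only, known or untested is meant among the compounds shown, and "the series" means these compounds.

Compound 1 `CCC(CC)S(=O)(=O)c1ccc(S(=O)(=O)N2CCC[C@@H](C(=O)N3CCC(F)(F)CC3)C2)cc1` gives the lowest number of the three measured compounds in a functional assay on BXPC-3 cells (Homo sapiens) for inhibition, read by MTT assay, with a stated time of 7 days (a lower number here means a stronger inhibitor, a higher number a weaker inhibitor), at 40 nM. Compound 2 `CCN(CC)S(=O)(=O)c1ccc(S(=O)(=O)N2CCC[C@@H](C(=O)N3CCC(OC)CC3)C2)cc1` gives 1420 nM in this assay, and compound 3 `CCN(CC)S(=O)(=O)c1ccc(S(=O)(=O)N2CCC[C@@H](C(=O)NC3COC3)C2)cc1` gives 13800 nM. Going by the values given here, the one single-point step known, a 9.7-fold higher number from compound 2 to compound 3 (0.99 log units; beyond the scatter), concerns the carbonyl end of the molecule, not the sulfonyl end. Compound 4 `CC(C)S(=O)(=O)c1ccc(S(=O)(=O)N2CCC[C@@H](C(=O)N3CCC(F)(F)CC3)C2)cc1` differs from compound 1 by isopropyl in place of pentan-3-yl on a sulfonyl sulfur. Among the compounds with values here, no measured step touches this sulfonyl group directly, since compound 2 differs from compound 1 in two places at once. With nothing bearing on it, the expected step of a 2.3-fold higher number from compound 1 to compound 4 (0.35 log units; beyond the scatter) is small, at most modest, and its direction is uncertain. Compound 4 is therefore estimated at 90 nM, within the range 25 nM to 350 nM.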

Compound 4, half-maximal inhibitory concentration: 50 nM
Beside the measured number, compound 4's estimate is 1.8-fold (0.26 log units) above it; the range from low to high includes it.
By their numbers in this assay, from the lowest: compounds 1 and 4 (each within the scatter of the next); then compound 2; then compound 3.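

Going by these compounds alone, compound 4 is the first direct test of this sulfonyl group, and replacing pentan-3-yl with isopropyl on the sulfonyl sulfur leaves the number in this assay within the scatter (a 1.3-fold higher number from compound 1 to compound 4 (0.10 log units; within the scatter)). The assay therefore does not separate these two alkyl groups at this position. No measurement at hand explains this match.

From the compounds shown here alone, whether methyl, or a chain ending in a carboxylic acid or an amine, would be accepted on this sulfur remains open. So does how much of the gap to compound 2 arises at each end of the molecule.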